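Propanoylpiperazine Urea Analogue: Expected Solubility

The source may report more compounds than this note shows. Statements on the series, on what has been measured and on what is new or still open speak of the compounds shown alone.

The three measured compounds share one core and differ only at a carbonyl carbon. In a physicochemical assay for solubility, read by HPLC, at pH 6.8 (a higher number here means a more soluble compound, a lower number a less soluble compound), compound 1 `CC(C)(C)c1cc(NC(=O)[C@@H]2CCCCN2C(=O)c2ccccc2)no1` gives 0.9 ug/mL, compound 2 `CC(C)(C)c1cc(NC(=O)[C@@H]2CCCCN2C(=O)C2CCOCC2)no1` gives 48 ug/mL and compound 3 `CC(C)(C)c1cc(NC(=O)[C@@H]2CCCCN2C(=O)N2CCCCC2)no1` gives 49 ug/mL. Compound 3 thus sits far above compound 1, as a 54-fold higher number from compound 1 to compound 3 (1.74 log units; beyond the scatter) shows, while a 1.0-fold higher number from compound 2 to compound 3 (0.01 log units; within the scatter) leaves compound 2 and compound 3 indistinguishable. Compound 4 `CCC(=O)N1CCN(C(=O)N2CCCC[C@H]2C(=O)Nc2cc(C(C)(C)C)on2)CC1` differs from compound 3 by 4-propanoylpiperazin-1-yl in place of piperidin-1-yl on a carbonyl carbon. Going by the values given here, no measured step covers this change directly; the only step at this carbon within the scatter, a 1.0-fold higher number from compound 2 to compound 3 (0.01 log units; within the scatter), exchanged two saturated rings, and the large rises both came from replacing phenyl. The expectation is therefore a modest step at most, a 1.6-fold higher number from compound 3 to compound 4 (0.21 log units; within the scatter), and compound 4 is estimated at 80 ug/mL, within 30 ug/mL to 200 ug/mL.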

Compound 4, solubility: 68 ug/mL
Estimate against measurement, compound 4: 1.2-fold (0.07 log units) above; the measured number falls inside the stated range.
By their numbers in this assay, from the lowest: compound 1; then compounds 2, 3 and 4 (each within the scatter of the next).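

In this assay, the carbonyl carbon now carries 4-propanoylpiperazin-1-yl, which has a hydrogen-bond acceptor where piperidin-1-yl has none, yet the number stays within the scatter of its neighbours (a 1.4-fold higher number from compound 3 to compound 4 (0.14 log units; within the scatter); a 1.4-fold higher number from compound 2 to compound 4 (0.15 log units; within the scatter)). The large gain over phenyl therefore extends to a third saturated ring (a 76-fold higher number from compound 1 to compound 4 (1.88 log units; beyond the scatter)), with no separation among compounds 2, 3 and 4. No evidence bears on why this is so. From the compounds shown here alone, whether a free amine or a carboxylic acid in place of the propanoyl group would move the number beyond the scatter remains open, as does the effect of a longer chain there.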